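The source may report more compounds than this note shows. Statements on the series, on what has been measured and on what is new or still open speak of the compounds shown alone.

Compound 1 `CCCCCCCCNc1ccc([N+](=O)[O-])cc1S(N)(=O)=O` gives 0.3% in an assay on HEK293 cells for inhibition of solute carrier family 12 member 2 (Homo sapiens), read by fluorescence, with a stated time of 30 min, tested at 10 uM; a lower number here means a weaker effect, a higher number a stronger effect of the compound at the concentration tested.
Compound 2 `CN(C)S(=O)(=O)c1cc([N+](=O)[O-])ccc1NCCC(C)(C)C` gives 10% in this assay.
Compound 3 `CCCCNc1ccc(C(=O)O)cc1S(=O)(=O)NC` gives 6.4% in this assay.

All three numbers are small, and none of the compounds shows much effect at the concentration tested. The number for compound 3 lies between those of compound 2 and compound 1, but both gaps are within the usual scatter of repeated measurements, so the three compounds cannot be told apart on these numbers.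

Compound 4 `CCCCCCCCNc1ccc(C(=O)O)cc1S(=O)(=O)NC` has not yet been measured. It differs from compound 3 in one place: butyl in place of hydrogen on a saturated chain carbon, four bonds along the chain from a nitrogen on an aromatic ring. Going by the values given here, no step between two measured compounds that differ in a single place is available, so there is no measured guide to the size of such a change. Because the three measured numbers, including 6.4% for compound 3, are all low and within scatter of each other, the expectation for compound 4 is a step of no more than the scatter, in no clear direction: a number 1.4 percentage points lower from compound 3 to compound 4 (within the scatter). For compound 4 the estimate in this assay is 5%, with a range from -5% to 16%.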

Compound 4, a percentage reported as inhibition, at one concentration (the size of the read-out at that concentration, not a potency): 16.2%
For compound 4 the middle estimate is 11.2 percentage points below the measured one; measured number above the stated range.
By their numbers in this assay, from the lowest: compounds 1, 3, 2 and 4 (each within the scatter of the next, the first and the last beyond it).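

Going by these compounds alone, this is the first step that changes a single place: butyl in place of hydrogen on a saturated chain carbon, four bonds along the chain from a nitrogen on an aromatic ring, gives a number 9.8 percentage points higher from compound 3 to compound 4 (within the scatter) in this assay. The two compounds therefore cannot be told apart, and this one step shows neither a clear gain nor a clear loss from adding butyl at this place. Nothing shown here accounts for the step.

From the compounds shown here alone, a single step cannot reveal a trend with chain size, so the effect of intermediate chains such as ethyl or propyl in place of hydrogen remains unknown. Going by these compounds, it also remains open whether a longer chain, or a chain ending in an amine, a hydroxyl or a phenyl ring, would move the read-out beyond the scatter.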